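From Isobutoxy to Fluoro in a Cytotoxicity Series

The source may hold more compounds than are shown below. What is called first, only, known or untested is meant among the compounds shown, and "the series" means these compounds.

In a functional assay on A549 cells (Homo sapiens) for cytotoxicity, with a stated time of 48 h (a higher number here means a weaker inhibitor, a lower number a stronger inhibitor), compound 1 (`CC(C)COc1ccc2oc(/C=C/[S+](C)[O-])cc(=O)c2c1`) gives 1100 nM and compound 2 (`Cc1c(/C=C/[S+](C)[O-])oc2ccccc2c1=O`) gives 1500 nM and these two values lie within the scatter of each other. Compound 3 (`COc1cccc2oc(/C=C/[S+](C)[O-])cc(=O)c12`) gives 3800 nM which is beyond the scatter from compound 1 on the weaker side. Compound 1 thus stands at the stronger end of this small set, alongside compound 2. Compound 4 (`C[S+]([O-])/C=C/c1cc(=O)c2cc(F)ccc2o1`) has not yet been measured and carries fluoro in place of isobutoxy on an aromatic carbon. For the measured compounds named here, no measured pair isolates this change, so only a modest shift toward weaker inhibition is expected in this assay and it may stay close to the scatter (a 2.0-fold higher number from compound 1 to compound 4 (0.30 log units; within the scatter)). Compound 4 is estimated at 2200 nM with a range from 800 nM to 6000 nM as the expected outcome.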

Compound 4, half-maximal inhibitory concentration: 2100 nM
Compound 4: middle estimate off by 1.0-fold (0.02 log units), on the high side; the measured number falls inside the stated range.
By their numbers in this assay, from the lowest: compounds 1, 2, 4 and 3 (each within the scatter of the next, the first and the last beyond it).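

For the compounds shown here, the step from isobutoxy to fluoro is the first single-place comparison, and in this assay it gives a 1.9-fold higher number from compound 1 to compound 4 (0.28 log units; within the scatter) for this aromatic carbon. A chain of five heavy atoms can thus give way to a single fluorine without a difference that this assay separates from its scatter, so the isobutoxy group is not shown to be needed here for this level of cytotoxicity.

Going by these compounds, whether an amine, a carboxylic acid or a longer alkoxy chain on this carbon would also stay within the scatter remains open. Nothing available bears on why isobutoxy and fluoro read alike here.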